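The source may hold more compounds than are shown below. What is called first, only, known or untested is meant among the compounds shown, and "the series" means these compounds.

Working notes on the series in a physicochemical assay for lipophilicity, measured as octanol-water partition; a lower number here means a more polar compound, a higher number a more lipophilic compound. Compound 1 `CC(O)COc1ccc(Cl)cc1Cl` gives 2.75. Compound 2 `OCC(O)COc1c(Cl)cccc1Cl` gives 1.88 in this assay. Compound 3 `OCC(O)COc1ccc(Cl)cc1Cl` gives 1.99 in this assay; the values of compound 3 and compound 2 lie within the scatter of each other. The difference between the cores of compound 2 and compound 3 is not broken down here. Compound 4 `CC(O)COc1c(Cl)cccc1Cl` is not yet measured.

The change from compound 3 to compound 1 is hydrogen in place of hydroxy on a saturated chain carbon, two bonds along the chain from an oxygen on a saturated carbon, with a step of a number 0.76 log units higher from compound 3 to compound 1 (beyond the scatter). The same change is made from compound 2 to compound 4, (hydrogen in place of hydroxy on a saturated chain carbon, two bonds along the chain from an oxygen on a saturated carbon), at a place described in the same words. The step from compound 2 to compound 4 in this assay is therefore expected to be a number 0.76 log units higher from compound 2 to compound 4 (beyond the scatter), which rests on a number 0.76 log units higher from compound 3 to compound 1 (beyond the scatter). Compound 4 is expected at 2.64, with ends 2.35 and 2.95.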

Compound 4, partition coefficient: 2.64
The estimate for compound 4 equals the measured number at the digits printed, within the range that was stated.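

The same change, hydrogen in place of hydroxy on a saturated chain carbon, gives in this assay a step of a number 0.76 log units higher from compound 2 to compound 4 (beyond the scatter), and a step of a number 0.76 log units higher from compound 3 to compound 1 (beyond the scatter) on the other core, so the step carries across these two cores at the digits printed. This rests on a single pair of cores and shows no general rule for the series. It also does not show what sets the size of the step, and nothing here bears on that.

Still open, going by these compounds, is whether a step of this size holds when an amine or a carboxylic acid enters in place of the hydroxy. The same question stands for a longer chain at this place.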